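The compounds below may be only part of what the source reports. "The series", "measured", "known", "first", "only" and "open" are said of these compounds alone.

Compound 1, `COc1ccc(NC[C@@H](O)COc2ccc(N3C[C@H](CNC(C)=O)OC3=O)cc2F)cc1`, in a physicochemical assay for solubility, read by HPLC (on this read-out lower numbers stand for lower solubility and higher numbers for higher solubility), gives 1300 nM.
Compound 2, `CC(=O)NC[C@H]1CN(c2ccc(OC[C@@H](O)CNc3ccc(C#N)cc3)c(F)c2)C(=O)O1`, in this assay gives 47000 nM.

Compound 2 stands highest of these two numbers; compound 1 is its nearest neighbour with a lower value, and that gap lies beyond the scatter. Compound 3, `CC(=O)NC[C@H]1CN(c2ccc(OC[C@H](O)CNc3ccc(C#N)cc3)c(F)c2)C(=O)O1`, differs from compound 2 only in how one centre is drawn: the two compounds have the same atoms and bonds and differ only in configuration as drawn: 1 of 2 stereo elements differ; a stereocentre at a saturated chain carbon is drawn S in compound 2 and R in compound 3. Among the compounds with values here, no step between two measured compounds shows what such a change does here. Because compound 2 gives 47000 nM and nothing enters or leaves, compound 3 is expected to stay close to it, with no step beyond the scatter in this assay. Compound 3 is estimated at 47000 nM, between 16000 nM and 140000 nM. The expected step is no change at the digits printed from compound 2 to compound 3 (within the scatter).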

Compound 3, solubility: 69000 nM
Beside the measured number, compound 3's estimate is 1.5-fold (0.17 log units) below it, and the stated range covers the measured number.
By their numbers in this assay, from the lowest: compound 1; then compounds 2 and 3 (each within the scatter of the next).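

With the saturated chain stereocentre drawn S or R, this assay shows no difference that stands out from the scatter: a 1.5-fold higher number from compound 2 to compound 3 (0.17 log units; within the scatter). This comparison tests that one centre alone, and it rests on: the fact that compounds 2 and 3 differ only in the configuration as drawn. Within the data shown here, with that centre the same in both compounds, cyano in place of methoxy on an aromatic carbon gives a 53-fold higher number from compound 1 to compound 3 (1.72 log units; beyond the scatter), the first single-place step of this size.

Going by these compounds, how an amine or a carboxylic acid on that aromatic carbon would read remains open. So does whether the stereocentre matters with methoxy in place of cyano.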